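The source may report more compounds than this note shows. Statements on the series, on what has been measured and on what is new or still open speak of the compounds shown alone.

Of the compounds shown here, three built on one shared core have been measured in a functional assay on K562 cells (Homo sapiens) for inhibition; a lower number here means a stronger inhibitor, a higher number a weaker inhibitor. Compound 1 `Cc1ccc(N2C(=O)C=CC2OCC(F)(F)F)cc1` gives 7140 nM. Compound 2 `O=C1C=CC(OCC(F)(F)F)N1c1ccc(Cl)cc1F` gives 6210 nM, and compound 3 `O=C1C=CC(OCC(F)(F)F)N1c1ccc(F)c(Cl)c1` gives 6320 nM. Compound 1 carries the highest of the three numbers, yet its gaps to compound 3 and to compound 2 both lie within the scatter, so the three sit together as far as this measurement can tell.

Compound 4 `O=C1C=CC(OCC(F)(F)F)N1c1ccc(Br)cc1` remains to be measured in this assay. It differs from compound 1 in a single place: bromo in place of methyl on an aromatic carbon. Going by the values given here, no measured pair shows this exact change, so no step can be read off for it. The values of compound 1, compound 2 and compound 3 show that varying the groups on the six-membered aromatic ring moved the number little, and compound 4 is expected to stay close to compound 1. The expected step is a 1.2-fold lower number from compound 1 to compound 4 (0.08 log units; within the scatter), not beyond the scatter in either direction. Compound 4 is therefore estimated at 6000 nM, within a range from 2500 nM to 14000 nM.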

Compound 4, half-maximal inhibitory concentration: 3270 nM
Compound 4: the middle estimate sits 1.8-fold (0.26 log units) above what was measured, and the stated range covers the measured number.
By their numbers in this assay, from the lowest: compounds 4, 2, 3 and 1 (each within the scatter of the next, the first and the last beyond it).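

In this assay, going by these compounds alone, bromo in place of methyl on an aromatic carbon, para to a large group, gives a 2.2-fold lower number from compound 1 to compound 4 (0.34 log units; beyond the scatter) and is the first single-place step that can be read. Within the data shown here, this modest step shows that the number does respond to what this position carries, which the values of the earlier compounds, all within the scatter of one another, had not revealed. No available evidence accounts for the step.

A single step cannot say whether the change is particular to bromo or would also appear with chloro, iodo or a longer chain at this position. As far as these compounds go, how an amine or a carboxylic acid at the same place would move the number also remains open, as does whether the step would carry over to other changes on the shared core.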